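Adding one carbon to the sulfur chain

A few compounds are considered here, and "the series" means these few. Any claim that something is new, unique, unknown or untested is made for them only; others in the source may bear on it.

compound 1 `CCSc1ccc(C2CC(=O)N2c2cc(OC)c(OC)c(OC)c2)cc1` gives 204 nM
compound 2 `COc1cc(N2C(=O)C(C3CC3)C2c2ccc(SC)cc2)cc(OC)c1OC` gives 279 nM

In a functional assay on HL-60 cells (Homo sapiens) for inhibition, read by resazurin assay, with a stated time of 72 h (on this read-out lower numbers stand for stronger inhibition and higher numbers for weaker inhibition), compound 2 lies within the usual scatter of compound 1 (204 nM). Compound 3 (`CCSc1ccc(C2C(C3CC3)C(=O)N2c2cc(OC)c(OC)c(OC)c2)cc1`) departs from compound 2 by a single change (methyl in place of hydrogen on a saturated chain carbon bound to a sulfur): methyl in place of hydrogen on a saturated chain carbon bound to a sulfur, so that methylsulfanyl becomes ethylsulfanyl. Compound 1 also carries ethylsulfanyl, and its value shows no separation from that of compound 2. In this assay the expected step (a 1.1-fold lower number from compound 2 to compound 3 (0.05 log units; within the scatter)) is therefore none beyond the scatter, with no clear direction. Compound 3 is estimated at 250 nM (range 120 nM to 520 nM).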

Compound 3, half-maximal inhibitory concentration: 803 nM
For compound 3 the middle estimate is 3.2-fold (0.51 log units) below the measured one; the whole stated range lies below it.
By their numbers in this assay, from the lowest: compounds 1 and 2 (each within the scatter of the next); then compound 3.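

In this assay, the change from methylsulfanyl to ethylsulfanyl is not neutral when cyclopropyl is present, giving a 2.9-fold higher number from compound 2 to compound 3 (0.46 log units; beyond the scatter) on this scaffold. With ethylsulfanyl held fixed, cyclopropyl in place of hydrogen on a saturated ring carbon gives a 3.9-fold higher number from compound 1 to compound 3 (0.60 log units; beyond the scatter), so the higher number appears with both groups together in compound 3. Nothing shown here explains this combined result.

The shown compounds leave open whether a longer chain on the sulfur would raise the number further. They also leave open how an amine in place of cyclopropyl would read.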